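Pyridin-3-yl in Place of Dichlorophenyl: an Expected Outcome

This account rests on a few compounds, and the source may have more. Where it says the series, first, only, none or still open, it means among the compounds named here.

Three compounds built on one shared core were tested in an assay on CHO cells for displacement of a labelled ligand from adenosine receptor A3 (Homo sapiens), read by scintillation counting, with a stated time of 120 min, tested at 10 uM; on this read-out lower numbers stand for less inhibition and higher numbers for more inhibition at the one concentration tested (going by the name of the read-out). Compound 1 `Nc1scc(CN2CCN(c3cc(Cl)cc(Cl)c3)CC2)c1C(=O)c1ccc(Cl)cc1` gives 1%, compound 2 `Nc1scc(CN2CCN(c3ccc(F)cc3Cl)CC2)c1C(=O)c1ccc(Cl)cc1` gives 0%, and compound 3 `Nc1scc(CN2CCN(c3ccccc3C(F)(F)F)CC2)c1C(=O)c1ccc(Cl)cc1` gives 0%. Compound 1 holds the largest of the three numbers, yet a number 1 percentage points lower from compound 1 to compound 2 (within the scatter) and a number 1 percentage points lower from compound 1 to compound 3 (within the scatter), so the three cannot be told apart; no change at the digits printed from compound 2 to compound 3 (within the scatter) likewise. Compound 4 `Nc1scc(CN2CCN(c3cccnc3)CC2)c1C(=O)c1ccc(Cl)cc1` has not yet been measured; it differs from compound 1 in one place: pyridin-3-yl in place of 3,5-dichlorophenyl on an amine nitrogen in a ring. Both earlier swaps at that same ring nitrogen shifted this assay by no more than the scatter, so this swap is expected to behave alike. Compound 4 is estimated to give 2% in this assay, between -6% and 10%. That estimate means a number 1 percentage points higher from compound 1 to compound 4 (within the scatter), expected to stay within the scatter.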

Compound 4, a percentage reported as inhibition, at one concentration (the size of the read-out at that concentration, not a potency): 0%
Beside the measured number, compound 4's estimate is 2 percentage points above it; low and high end bracket the measured number.
By their numbers in this assay, from the lowest: compounds 2, 3, 4 and 1 (each within the scatter of the next).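

In this assay, a ring carrying a hetero atom and a hydrogen-bond acceptor, with no chlorine, now sits on this amine nitrogen, and pyridin-3-yl in place of 3,5-dichlorophenyl gives a number 1 percentage points lower from compound 1 to compound 4 (within the scatter) as its result. The comparisons with the other two rings read the same, with no change at the digits printed from compound 3 to compound 4 (within the scatter) and no change at the digits printed from compound 2 to compound 4 (within the scatter) as well. Nothing available offers a reason for these numbers.

Going by these compounds, all four compounds carry an aromatic ring on this nitrogen, so an ethyl chain, a carboxylic acid or an amine there remains open. Also open, on these data alone, is whether changes elsewhere on the shared core would alter the reading.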